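The source may report more compounds than this note shows. Statements on the series, on what has been measured and on what is new or still open speak of the compounds shown alone.

Measured in a functional assay on PC-3 cells (Homo sapiens) for inhibition, read by sulforhodamine B assay, with a stated time of 72 h; on this read-out higher numbers stand for weaker inhibition and lower numbers for stronger inhibition:

- Compound 1 `Nc1sc(-c2ccc(Cl)cc2)c(-c2ccc(Cl)cc2)c1C(=O)NC1CCCCC1` gives 7300 nM
- Compound 2 `Nc1sc(-c2ccc(Cl)cc2)c(-c2ccc(Cl)cc2)c1C(=O)Nc1ccccc1` gives > 50000 nM, which is a limit of the assay and not a number
- Compound 3 `CCCCNC(=O)c1c(N)sc(-c2ccc(Cl)cc2)c1-c1ccc(Cl)cc1` gives 17800 nM

Compound 3 holds the higher of the two actual numbers, and the nearest value to it belongs to compound 1. Compound 4 `COc1ccc(CNC(=O)c2c(N)sc(-c3ccc(Cl)cc3)c2-c2ccc(Cl)cc2)cc1` differs from compound 3 by having 4-methoxyphenyl in place of propyl on a saturated chain carbon bound to an amide-type nitrogen. In other words, butyl gives way to 4-methoxybenzyl.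

Three measured steps change the group on this same nitrogen. Two end at the butyl compound and run in opposite directions: a 2.4-fold higher number from compound 1 to compound 3 (0.39 log units; beyond the scatter), and an at least 2.8-fold lower number from compound 2 to compound 3 (0.44 log units; beyond the scatter). The third spans the ring-bearing pair: an at least 6.8-fold higher number from compound 1 to compound 2 (0.83 log units; beyond the scatter). Among the measured compounds shown here, since compound 1 and compound 2 fall on opposite sides of compound 3, a ring in this group sets no direction, so no step clearly beyond the scatter is expected in this assay. The expected step is a 1.2-fold lower number from compound 3 to compound 4 (0.07 log units; within the scatter). Compound 4 is estimated at 15000 nM, within an expected range of 5500 nM to 45000 nM.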

Compound 4, half-maximal inhibitory concentration: 29500 nM
For compound 4 the middle estimate is 2.0-fold (0.29 log units) below the measured one; the range from low to high includes it.
By their numbers in this assay, from the lowest: compound 1; then compounds 3 and 4 (each within the scatter of the next). At a limit, above all of these: compound 2.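

In this assay, 4-methoxybenzyl on the amide-type nitrogen cannot be told apart from butyl, a 1.7-fold higher number from compound 3 to compound 4 (0.22 log units; within the scatter), so a chain ending in a 4-methoxyphenyl ring reads like the open chain here. Cyclohexyl, by contrast, keeps a clear edge over this new group, a 4.0-fold higher number from compound 1 to compound 4 (0.61 log units; beyond the scatter), and compound 1 now holds the lowest number of the four, with its steps to all the others beyond the scatter. Compound 2 stands at > 50000 nM, which is a limit of the assay and not a number, and an at least 1.6-fold lower number from compound 2 to compound 4 (0.22 log units; that floor lies within the scatter) says little about phenyl against 4-methoxybenzyl because only a floor can be read: the limit of > 50000 nM in this assay, at which 1 of the 4 values shown sits.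

The compounds shown leave open whether plain benzyl, without the methoxy, would read the same as compound 4. They also leave open whether cyclopentyl would keep the edge of cyclohexyl, and what an amine or a carboxylic acid at the end of the chain would do.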